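The compounds below may be only part of what the source reports. "The series", "measured", "known", "first", "only" and "open" are said of these compounds alone.

Of the compounds shown here, three sharing one core have been measured in an ADME assay on microsomes from liver (Homo sapiens) for metabolic stability, read by HPLC, with a stated time of 30 min, tested at 0.5 uM; on this read-out higher numbers stand for fast clearance and lower numbers for slow clearance. Compound 1 `CCC/N=C1\S/C(=C\c2ccc(O)cc2)C(=O)N1c1ccccc1C` gives 2.4 mL.min-1.g-1, compound 3 `CCC/N=C1\S/C(=C\c2ccc(O)c(C)c2)C(=O)N1c1ccccc1C` gives 2.8 mL.min-1.g-1, and compound 2 `CCC/N=C1\S/C(=C\c2ccc(O)c(C(F)(F)F)c2)C(=O)N1c1ccccc1C` gives 1 mL.min-1.g-1. Compound 1 therefore sits with compound 3 at the high end of this small set, the two lying within the scatter of each other, while compound 2 stands alone at the low end.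

The unmeasured compound 4 `CCC/N=C1\S/C(=C\c2ccc(O)c(Cl)c2)C(=O)N1c1ccccc1C` differs from compound 1 by a single change: chloro in place of hydrogen on an aromatic carbon. In words, this is chloro in place of hydrogen on an aromatic carbon, ortho to a hydroxy group, turning 4-hydroxyphenyl into 3-chloro-4-hydroxyphenyl.

Going by the values given here, two measured steps bear on this change, as each replaces the same hydrogen. Methyl gives a 1.2-fold higher number from compound 1 to compound 3 (0.07 log units; within the scatter), whereas trifluoromethyl gives a 2.4-fold lower number from compound 1 to compound 2 (0.38 log units; beyond the scatter). These two groups are themselves separated by a 2.8-fold higher number from compound 2 to compound 3 (0.45 log units; beyond the scatter). With only these two examples, pointing in different directions, chloro is expected to land somewhere between them, and a small downward shift is the most likely outcome. The expected step is a 1.4-fold lower number from compound 1 to compound 4 (0.15 log units; within the scatter), which would not clearly stand out from the scatter. Compound 4 is estimated at 1.7 mL.min-1.g-1, with an expected range from 0.9 mL.min-1.g-1 to 3.2 mL.min-1.g-1.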

Compound 4, intrinsic clearance in microsomes: 1.6 mL.min-1.g-1
Compound 4: middle estimate off by 1.1-fold (0.03 log units), on the high side; measured number inside the range.
By their numbers in this assay, from the lowest: compounds 2, 4, 1 and 3 (each within the scatter of the next, the first and the last beyond it).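

In this assay, chloro on this aromatic carbon, ortho to a hydroxy group, gives a 1.5-fold lower number from compound 1 to compound 4 (0.18 log units; within the scatter), so this third replacement of the same hydrogen produces a step that cannot be told apart from repeat-measurement noise. The new compound also connects two groups that had looked distinct: methyl and trifluoromethyl are clearly separated, with a 2.8-fold higher number from compound 2 to compound 3 (0.45 log units; beyond the scatter), yet chloro cannot be separated from either, with a 1.8-fold lower number from compound 3 to compound 4 (0.24 log units; within the scatter) and a 1.6-fold higher number from compound 2 to compound 4 (0.20 log units; within the scatter), so the series now reads as a continuous spread at this position rather than two separate levels. Nothing available explains why these groups give these numbers.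

From the compounds shown here alone, with only methyl, trifluoromethyl and chloro at this position, it remains open whether a group such as fluoro, methoxy, a nitrile or an amine would fall inside the same spread or outside it. The compounds shown also all keep the same chain on the shared core, so they cannot say whether these steps would hold with a longer chain there.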